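Methoxy for fluoro on a 2,5-diaryl indole cytotoxicity series

A few compounds are considered here, and "the series" means these few. Any claim that something is new, unique, unknown or untested is made for them only; others in the source may bear on it.

Of the compounds shown here, three of a shared core have been tested in a functional assay on HeLa cells (Homo sapiens) for cytotoxicity, read by MTT assay, with a stated time of 2 days, tested at 10 uM; a higher number here means a weaker effect of the compound at the concentration tested, a lower number a stronger effect. Compound 1 `CC(=O)c1cc(-c2ccccc2)cc2cc(-c3ccc(F)cc3)[nH]c12` gives 76.9%. Compound 2 `COc1ccc(-c2cc3cc(-c4ccccc4)cc(C(C)=O)c3[nH]2)cc1` gives 51.6%, and compound 3 `COc1ccc(-c2cc3cc(-c4ccc(F)cc4)cc(C(C)=O)c3[nH]2)cc1` gives 52%. The step of a number 25.3 percentage points lower from compound 1 to compound 2 (beyond the scatter) corresponds to the change (methoxy in place of fluoro on an aromatic carbon), while the step of a number 0.4 percentage points higher from compound 2 to compound 3 (within the scatter) corresponds to a fluoro in place of hydrogen on an aromatic carbon. How the core of compound 3 differs from that of compound 1 is not broken down here.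

Compound 4 `COc1ccc(-c2cc(C(C)=O)c3[nH]c(-c4ccc(OC)cc4)cc3c2)cc1` has not yet been measured in this assay. It differs from compound 3 by methoxy in place of fluoro on an aromatic carbon, the same change that led from compound 1 to compound 2. Because the earlier step of a number 25.3 percentage points lower from compound 1 to compound 2 (beyond the scatter) was modest and beyond the scatter, a comparable direction is expected here, though the placement of fluoro in compound 3 left the number essentially unchanged by a number 0.4 percentage points higher from compound 2 to compound 3 (within the scatter), so a smaller step is estimated: a number 10 percentage points lower from compound 3 to compound 4 (within the scatter). Compound 4 is expected to give about 42%, with a range from 25% to 60%.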

Compound 4, a percentage reported as activity, at one concentration (the size of the read-out at that concentration, not a potency): 37.1%
Compound 4: the middle estimate sits 4.9 percentage points above what was measured; the range from low to high includes it.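

In this assay, the exchange of 4-fluorophenyl for 4-methoxyphenyl gives a number 14.9 percentage points lower from compound 3 to compound 4 (beyond the scatter), in the same direction as the earlier step on the core of compound 1, and the two steps do not differ by more than their scatter: the same change on two cores in this assay, a number 25.3 percentage points lower (beyond the scatter) from compound 1 to compound 2 and a number 14.9 percentage points lower (beyond the scatter) from compound 3 to compound 4, 10.4 percentage points apart, within the scatter of two such steps. Seen from the other side, methoxy in place of hydrogen gives a number 14.5 percentage points lower from compound 2 to compound 4 (beyond the scatter), whereas fluoro in place of hydrogen gives only a number 0.4 percentage points higher from compound 2 to compound 3 (within the scatter). This supports the change carrying over between these two cores at the single concentration tested, but two cores cannot show that it holds on others, and a read-out at one concentration gives no potency and no reason for the step.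

The compounds shown leave open how an amine or a hydroxyl in place of the methoxy would read on the same core. From the compounds shown here alone, all four compounds also carry the acetyl group, so the effect of an amide or a carboxylic acid there remains unknown.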